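Phenyl in Place of Iodo on Two Related Cores

The source may report more compounds than this note shows. Statements on the series, on what has been measured and on what is new or still open speak of the compounds shown alone.

Compound 1 `Cc1nc(N)c2c(-c3ccccc3)cn([C@@H]3O[C@H](CO)[C@@H](O)[C@H]3O)c2n1`: in an ADME assay on MRC5 cells (Homo sapiens), read by MTT assay, with a stated time of 72 h (a lower number here means a stronger inhibitor, a higher number a weaker inhibitor), compound 1 reaches only the assay limit > 100000 nM.
Compound 2 `Cc1nc(N)c2c(I)cn([C@@H]3O[C@H](CO)[C@@H](O)[C@H]3O)c2n1`: in this assay compound 2 gives 85800 nM.
Compound 3 `CNc1ncnc2c1c(I)cn2[C@@H]1O[C@H](CO)[C@@H](O)[C@H]1O`: in this assay compound 3 reaches only the assay limit > 100000 nM.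

Compound 2 and compound 1 differ by one change, (phenyl in place of iodo on an aromatic carbon), and the measured step is an at least 1.1-fold higher number from compound 2 to compound 1 (0.06 log units; that floor lies within the scatter). Of the three values shown, (the limit of > 100000 nM in this assay, at which 2 of the 3 values shown sit), so the number for compound 1 is a limit and not a measurement. The two cores, that of compound 2 and that of compound 3, are built from the same atoms joined differently; the difference between them is not broken down here.

Compound 4 `CNc1ncnc2c1c(-c1ccccc1)cn2[C@@H]1O[C@H](CO)[C@@H](O)[C@H]1O` carries the same kind of change on the core of compound 3, namely (phenyl in place of iodo on an aromatic carbon), and has not been measured in this assay. The step expected here is a step that the limit leaves unreadable from compound 3 to compound 4, which rests on the measured step of an at least 1.1-fold higher number from compound 2 to compound 1 (0.06 log units; that floor lies within the scatter) and on compound 3 already sitting at its limit > 100000 nM. Compound 4 is therefore estimated at about 150000 nM, between 60000 nM and 400000 nM.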

Compound 4, half-maximal inhibitory concentration: > 100000 nM
Compound 4 ended at the assay's limit (the forecaster's own chance of this, stated with the estimate: 80%); the middle value lies beyond the limit too.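

In this assay, compound 3 and compound 4 both stand at a limit and not at a measured number, so no step can be read for phenyl in place of iodo on this core: the limit of > 100000 nM in this assay, at which 3 of the 4 values shown sit.

The compounds shown leave open what actual numbers compound 3 and compound 4 have, and whether this change shifts the number on that core at all.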